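From Methoxy to Ethoxy at the Assay Limit

The compounds below may be only part of what the source reports. "The series", "measured", "known", "first", "only" and "open" are said of these compounds alone.

In a functional assay on thoracic aorta (Rattus norvegicus, strain Wistar), with a stated time of 15 min (on this read-out lower numbers stand for an effect already at smaller amounts and higher numbers for an effect only at larger amounts of compound), compound 2 `COc1ccc(Cl)cc1C(C)NC(=O)NS(=O)(=O)c1ccc(Cl)cc1` gives > 300000 nM, which is a limit and not a number. Compound 1 `COc1ccc(Cl)cc1C(C)NC(=O)NS(=O)(=O)c1ccccc1` gives > 300000 nM, also a limit. Compound 3 `COc1ccc(F)cc1C(C)NC(=O)NS(=O)(=O)c1ccc(Cl)cc1` gives > 300000 nM, again a limit. The whole picture is therefore (the limit of > 300000 nM in this assay, at which 3 of the 3 values shown sit). Compound 4 `CCOc1ccc(Cl)cc1C(C)NC(=O)NS(=O)(=O)c1ccc(Cl)cc1` differs from compound 2 by methyl in place of hydrogen on a saturated chain carbon bound to an oxygen on an aromatic ring, which turns methoxy into ethoxy. Two measured steps could bear on this change, a step that the two limits leave unreadable from compound 1 to compound 2 and a step that the two limits leave unreadable from compound 2 to compound 3, and both are halogen changes on an aromatic carbon. Neither gives a size or a direction, so no step beyond the scatter is expected. The estimated change is a number no higher from compound 2 to compound 4 (the limit leaves the size open). Compound 4 is expected near 300000 nM, with an estimated range from 100000 nM to 500000 nM.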

Compound 4, half-maximal effective concentration: 281000 nM
Estimate against measurement, compound 4: 1.1-fold (0.03 log units) above; low and high end bracket the measured number.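

Going from methoxy to ethoxy, on the saturated chain carbon bound to an oxygen on an aromatic ring, yields the first real number in this assay, whereas the earlier halogen steps cannot be read. The change gives an at least 1.0-fold lower number from compound 2 to compound 4 (0.02 log units; that floor lies within the scatter), so only a floor is known, and it does not separate the two compounds. Most of the series still sits at the edge of this read-out: the limit of > 300000 nM in this assay, at which 3 of the 4 values shown sit.

Going by these compounds, whether a longer chain such as propoxy, or an amine at this place, would shift the number beyond the usual scatter stays open.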